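One More Methyl on the Aromatic Ring

A few compounds are considered here, and "the series" means these few. Any claim that something is new, unique, unknown or untested is made for them only; others in the source may bear on it.

In a functional assay on KB cells (Homo sapiens) for cytotoxicity (a higher number here means that more compound is needed for the effect, a lower number that less compound is needed), compound 1 `COC1=C(C)C(=O)/C(=C(O)/C=C/c2ccc(C)cc2)C(=O)C1(C)C` gives 3.9 ug/mL and compound 2 `COC1=C(C)C(=O)/C(=C(O)/C=C/c2c(C)cccc2C)C(=O)C1(C)C` gives 7.1 ug/mL on the shared core. These two numbers lie within the scatter of each other, so compound 2 holds no distinct place in this pair.

Compound 3 `COC1=C(C)C(=O)/C(=C(O)/C=C/c2c(C)cc(C)cc2C)C(=O)C1(C)C` follows from compound 2 through methyl in place of hydrogen on an aromatic carbon with methyl in place of hydrogen on an aromatic carbon, meta to two methyl groups and para to a large group. Within the data shown here, no measured step isolates exactly this change. Among the measured compounds shown here, the only measured step that bears on it is a 1.8-fold higher number from compound 1 to compound 2 (0.26 log units; within the scatter) where 2,6-dimethylphenyl replaces 4-methylphenyl on the same kind of ring. That step stays within the scatter, so it gives no ground to expect a large move from one further methyl. The step expected in this assay is a 1.1-fold lower number from compound 2 to compound 3 (0.04 log units; within the scatter) and nothing beyond the scatter is anticipated. Compound 3 is estimated at 6.5 ug/mL with an expected range from 2.8 ug/mL to 15 ug/mL in this measurement.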

Compound 3, concentration for half-maximal effect: > 20 ug/mL
Compound 3 gave a limit, no number; the forecaster's own chance of this, stated with the estimate: 3%; at least 3.0-fold (0.48 log units) between middle value and limit.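

In this assay, the methyl group entering on the aromatic carbon meta to two methyl groups and para to a large group brings the first step among these compounds that lies beyond the scatter: an at least 2.8-fold higher number from compound 2 to compound 3 (0.44 log units; beyond the scatter). The earlier step, a 1.8-fold higher number from compound 1 to compound 2 (0.26 log units; within the scatter), stayed within the scatter, and so it gave no sign that a single added carbon on this aromatic ring could move the reading this far. The reading for compound 3 is a limit and not a number, and the step built on it therefore gives only a lower bound on the change: the limit of > 20 ug/mL in this assay, at which 1 of the 3 values shown sits.

What lies behind the step stays unknown, and so does its dependence on the two methyl groups, as compound 1 also carries a methyl group at this place but differs from compound 3 in more than one place. The compounds shown also leave open whether a methoxy group, a chlorine atom or a longer chain such as ethyl on this same aromatic carbon would give a readable number in this assay or another limit.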